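Anticonvulsant Screening of Triazole-Thione Compounds: Predicting Compound 4

The source may report more compounds than this note shows. Statements on the series, on what has been measured and on what is new or still open speak of the compounds shown alone.

Measured so far:
compound 1 `COc1ccc(-n2c(Nc3nc(-c4ccc([N+](=O)[O-])cc4)cs3)n[nH]c2=S)cc1` — 100 mg/kg
compound 2 `COc1ccccc1-n1c(Nc2nc(-c3ccccc3)cs2)n[nH]c1=S` — 100 mg/kg
compound 3 `COc1ccc(-n2c(Nc3nc(-c4ccccc4)cs3)n[nH]c2=S)cc1` — 100 mg/kg

Of the compounds shown here, three sharing one core have been tested in a functional assay on the whole organism (strain Swiss albino) for inhibition, with Mus musculus as the target, with a stated time of 0.5 h; a lower number here means that less compound is needed, a higher number that more compound is needed for the effect. In this assay compound 1 gives 100 mg/kg, compound 2 gives 100 mg/kg and compound 3 gives 100 mg/kg. Among the measured compounds shown here, compound 3 therefore stands level with both of its neighbours: the step of no change at the digits printed from compound 1 to compound 3 (within the scatter) and the step of no change at the digits printed from compound 2 to compound 3 (within the scatter) are each within the scatter, so no compound among the three can be called more or less active than another.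

The next compound, compound 4 `Cc1ccccc1-n1c(Nc2nc(-c3ccccc3)cs2)n[nH]c1=S`, differs from compound 3 in one place:

2-methylphenyl in place of 4-methoxyphenyl on an aromatic nitrogen

For the measured compounds named here, of the measured steps, the one from compound 2 to compound 3 is the closest in kind, since it also exchanges one group on the same aromatic nitrogen, and it showed no change at the digits printed from compound 2 to compound 3 (within the scatter). Going by the values given here, no measured pair exchanges a methoxy group for a methyl group, so that part of the change has no direct precedent. On the evidence to hand, compound 4 is expected to show no step beyond the scatter, no change at the digits printed from compound 3 to compound 4 (within the scatter), in this assay. Compound 4 is thus estimated at 100 mg/kg, with a likely range from 50 mg/kg to 200 mg/kg.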

Compound 4, minimum effective dose: 100 mg/kg
Compound 4: middle estimate and measured number agree at the digits printed; low and high end bracket the measured number.
By their numbers in this assay, from the lowest: compounds 1, 2, 3 and 4 (each within the scatter of the next).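

Among the compounds shown here, compound 4 adds a comparison the earlier compounds did not offer, an exchange of the substituent itself at the same place on the aryl ring: with methyl in place of methoxy on an aromatic carbon, this assay shows no change at the digits printed from compound 2 to compound 4 (within the scatter), so removing the oxygen of that substituent leaves the read-out level here. The exchange of 4-methoxyphenyl for 2-methylphenyl on the aromatic nitrogen, which alters both the substituent and where it sits, likewise gives no change at the digits printed from compound 3 to compound 4 (within the scatter), and so all the aryl groups shown on that nitrogen stand level in this assay. No supporting data are available to explain why these exchanges leave the read-out level.

The compounds shown leave open whether a quite different substituent on this aryl ring, such as an amine, a carboxylic acid or a longer chain in place of the methyl, would move the value away from that of compound 4. They also leave open whether any group on this aromatic nitrogen can separate one compound from another in this assay, since the four compounds shown do not differ beyond the scatter.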